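Piperidinyl in place of nitro on compound 2

The source may report more compounds than this note shows. Statements on the series, on what has been measured and on what is new or still open speak of the compounds shown alone.

Compound 2 `Cc1cnc(Nc2ccc([N+](=O)[O-])cc2)nc1Nc1nc2ccccc2s1` is one of three members of the series measured in a functional assay on HeLa cells (Homo sapiens) for antiproliferative activity, read by MTT assay, with a stated time of 48 h; a lower number here means a stronger inhibitor, a higher number a weaker inhibitor. Compound 1 `COc1ccc2nc(Nc3ccnc(Nc4ccc(S(N)(=O)=O)cc4)n3)sc2c1` gives 1730 nM in this assay, whereas compound 2 gives 34300 nM, the highest of the two numbers read; the gap to compound 1 lies beyond the scatter. Compound 3 `COc1cccc(Nc2ncc(C)c(Nc3nc4ccccc4s3)n2)c1` in this assay is reported only as a limit, > 50000 nM. Within the data shown here, the single measured step in one place, an at least 1.4-fold higher number from compound 2 to compound 3 (0.16 log units; that floor lies within the scatter), rests on that limit, (the limit of > 50000 nM in this assay, at which 1 of the 3 values shown sits), so its true size is unknown beyond the floor.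

Compound 4 `Cc1cnc(Nc2ccc(N3CCCCC3)cc2)nc1Nc1nc2ccccc2s1` differs from compound 2 by piperidin-1-yl in place of nitro on an aromatic carbon. The measured step changed the whole aryl and moved the substituent, so it bears only loosely on the present change, which keeps the aryl and exchanges the group sitting para to a large group. Among the measured compounds shown here, compound 1 and compound 2 differ in more than one place; their values show only that another para group on a differently substituted core reads lower. For the measured compounds named here, with no direct precedent, the step is expected to be modest and its direction uncertain, a 1.7-fold lower number from compound 2 to compound 4 (0.23 log units; within the scatter). For compound 4 in this assay the estimate is 20000 nM, within 5000 nM to 50000 nM.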

Compound 4, half-maximal inhibitory concentration: 4340 nM
Compound 4: middle estimate off by 4.6-fold (0.66 log units), on the high side, outside the stated range (below it).
By their numbers in this assay, from the lowest: compound 1; then compound 4; then compound 2. At a limit, above all of these: compound 3.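

In this assay, piperidin-1-yl in place of nitro on the aromatic carbon gives a 7.9-fold lower number from compound 2 to compound 4 (0.90 log units; beyond the scatter), a step that lies beyond the scatter. This is the only step shown that keeps the aryl and the shared core and changes just the group para to a large group, so it shows that the number in this assay responds to the group at this position alone, and that a six-membered non-aromatic ring can sit there with the number falling rather than rising. The earlier step, which exchanged the whole aryl and moved the substituent, gives only a floor and no size, since compound 3 is reported only as a limit: the limit of > 50000 nM in this assay, at which 1 of the 4 values shown sits.

One pair cannot tell whether the lower number comes from the ring of piperidin-1-yl, from its nitrogen attached to the aryl, or simply from the departure of nitro. Morpholine, a dimethylamino group or a plain hydrogen at the same position would separate these readings, and whether the step carries over to the core of compound 1 remains open.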